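Series notes: from compound 3 to compound 4

The source may report more compounds than this note shows. Statements on the series, on what has been measured and on what is new or still open speak of the compounds shown alone.

Among the measured compounds shown here, compound 3 `O=C1/C(=C\c2cccc(Br)c2)c2ccccc2N1c1c(Cl)cccc1Cl` gives 5 ug/mL in a functional assay on MIA PaCa-2 cells (Homo sapiens) for cytotoxicity, read by MTT assay, with a stated time of 72 h (a higher number here means that more compound is needed for the effect, a lower number that less compound is needed), the only number among the three measured compounds. Compound 1 `O=C1/C(=C\c2cccc(Oc3ccccc3)c2)c2ccccc2N1c1c(Cl)cccc1Cl` sits at the limit > 100 ug/mL in this assay. Compound 2 `CN(C)c1ccc(/C=C2\C(=O)N(c3c(Cl)cccc3Cl)c3ccccc32)cc1` also sits at the limit > 100 ug/mL in this assay. The steps of an at least 20-fold lower number from compound 1 to compound 3 (1.30 log units; beyond the scatter) and an at least 20-fold lower number from compound 2 to compound 3 (1.30 log units; beyond the scatter) are both large and both run toward compound 3, shaped by the limit of > 100 ug/mL in this assay, at which 2 of the 3 values shown sit. Compound 4 `O=C1/C(=C\c2ccc(Cl)cc2)c2ccccc2N1c1c(Cl)cccc1Cl` differs from compound 3 by 4-chlorophenyl in place of 3-bromophenyl on a double-bonded chain carbon bound to a double-bonded ring carbon. Neither measured step exchanges one halogen-bearing phenyl for another, so they bear on this change only in showing that the halogen-bearing phenyl of compound 3 carries the number; in this assay no step beyond the scatter is expected in either direction. The expected value for compound 4 is 5 ug/mL, with a range from 2 ug/mL to 15 ug/mL. The expected step is no change at the digits printed from compound 3 to compound 4 (within the scatter).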

Compound 4, concentration for half-maximal effect: 5 ug/mL
For compound 4 middle estimate and measured number coincide at the digits printed; low and high end bracket the measured number.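

In this assay, 4-chlorophenyl in place of 3-bromophenyl on the double-bonded chain carbon gives no change at the digits printed from compound 3 to compound 4 (within the scatter), so this place accepts either halogen-bearing phenyl without a step beyond the scatter. Chloro in place of dimethylamino on an aromatic carbon gives an at least 20-fold lower number from compound 2 to compound 4 (1.30 log units; beyond the scatter). Compound 2 stands at a limit, not a number, which bounds that step: the limit of > 100 ug/mL in this assay, at which 2 of the 4 values shown sit.

The halogen and its place on the ring change together from compound 3 to compound 4, so neither can be read alone. As far as these compounds go, how an unsubstituted phenyl, or a phenyl carrying a carboxylic acid, would behave at this place stays open.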